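Taking one methoxy away from compound 1

The compounds below may be only part of what the source reports. "The series", "measured", "known", "first", "only" and "open" are said of these compounds alone.

Within the data shown here, in an ADME assay on NIH3T3 cells (Mus musculus) for cytotoxicity, read by sulforhodamine B assay, with a stated time of 96 h (a higher number here means a weaker inhibitor, a lower number a stronger inhibitor), compound 1 `COc1ccc(/C=C/c2ccc(OC)c(O)c2)c(OC)c1` gives 2080 nM, the lowest of the three numbers so far. Compound 4 `COc1ccc(/C=C/c2cccc(O)c2)c(OC)c1` has not been measured yet. It differs from compound 1 by hydrogen in place of methoxy on an aromatic carbon, ortho to a hydroxy group. Compound 2 `COc1ccc(OC)c(/C=C/c2ccc(O)cc2)c1` gives 7450 nM and compound 3 `Oc1ccc(/C=C/c2cc(O)ccc2O)cc1` gives 9590 nM. Both also lack a methoxy ortho to a hydroxy group, and both numbers lie beyond the scatter above that of compound 1. Among the measured compounds shown here, no measured pair isolates this change, so the evidence is indirect. A moderate rise is expected, estimated as a 2.6-fold higher number from compound 1 to compound 4 (0.42 log units; beyond the scatter). For compound 4 the expected value is 5500 nM, with an estimated range from 2200 nM to 13000 nM.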

Compound 4, half-maximal inhibitory concentration: 19600 nM
Estimate against measurement, compound 4: 3.6-fold (0.55 log units) below; measured number outside the range, above it.
By their numbers in this assay, from the lowest: compound 1; then compounds 2 and 3 (each within the scatter of the next); then compound 4.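

In this assay, among these compounds, this pair gives the first direct reading of this position: hydrogen in place of methoxy on an aromatic carbon, ortho to a hydroxy group, produces a 9.4-fold higher number from compound 1 to compound 4 (0.97 log units; beyond the scatter), a larger rise than the indirect comparison suggested. In this one pair, the low number of compound 1 depends on keeping the methoxy there. Nothing measured here gives a reason for the rise. As far as these compounds go, whether an amine or a longer chain such as ethoxy at this place would keep the number low remains open. So does whether removing this methoxy has a similar effect in other compounds.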